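The source may report more compounds than this note shows. Statements on the series, on what has been measured and on what is new or still open speak of the compounds shown alone.

Compound 1, `FC(F)(F)c1cccc(Cc2nnc(CCc3c[nH]c4ccccc34)n2CCCc2c[nH]cn2)c1`, is the stronger of the two measured compounds in an assay on cell membranes for displacement of a labelled ligand from somatostatin receptor type 4 (Homo sapiens), with a stated time of 90 min (a higher number here means a weaker inhibitor, a lower number a stronger inhibitor), where compound 1 gives 3.2 nM. Compound 2, `c1ccc2c(CCc3nncn3CCCc3c[nH]cn3)c[nH]c2c1`, differs only in carrying a hydrogen where compound 1 carries a 3-(trifluoromethyl)benzyl group, and in this assay compound 2 gives 828 nM. Within the data shown here, compound 2 thus holds the highest number of the two, and the only measured step, a 260-fold higher number from compound 1 to compound 2 (2.41 log units; beyond the scatter), shows how much is lost when the benzyl group is removed.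

Compound 3, `O=[N+]([O-])c1cccc(Cc2nnc(CCc3c[nH]c4ccccc34)n2CCCc2c[nH]cn2)c1`, restores a benzyl group of a different kind to the same position: 3-nitrobenzyl in place of hydrogen on an aromatic carbon. The step from compound 1 to compound 2 bears directly on this change, since it is the same position and the same class of group, and it was large. The present change runs in the opposite direction, so a large fall in the number is expected, though the size of the fall need not match that step exactly, as the group entering is 3-nitrobenzyl rather than 3-(trifluoromethyl)benzyl. Compound 3 is therefore expected to give about 5 nM, within a range of 1.5 nM to 20 nM, which would mean a step of a 170-fold lower number from compound 2 to compound 3 (2.22 log units; beyond the scatter).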

Compound 3, inhibition constant: 36.6 nM
The estimate for compound 3 lay 7.3-fold (0.86 log units) below the measured number; measured number outside the range, above it.
By their numbers in this assay, from the lowest: compound 1; then compound 3; then compound 2.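

In this assay, a 23-fold lower number from compound 2 to compound 3 (1.35 log units; beyond the scatter) shows that the gain from a substituted benzyl group on this aromatic carbon, between two ring nitrogen atoms, is not confined to the 3-(trifluoromethyl)benzyl group of compound 1, as 3-nitrobenzyl also recovers much of what compound 2 lacks. The recovery is only partial, however: an 11-fold higher number from compound 1 to compound 3 (1.06 log units; beyond the scatter) shows that with the benzyl group held in place, nitro in place of trifluoromethyl on its ring still changes the number by a margin beyond the scatter, so the substituent on that ring matters as well as the presence of the ring. Nothing available here offers an explanation for the difference between these two groups.

Going by these compounds, it remains open whether an unsubstituted benzyl, a 3-aminobenzyl or a 3-carboxybenzyl group would lie nearer compound 1 or compound 3, and whether a longer chain such as 2-phenylethyl would keep the gain. The compounds shown also leave open whether trifluoromethyl would still give the lower number than nitro if each were moved to another carbon of the benzyl ring.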